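A few compounds are considered here, and "the series" means these few. Any claim that something is new, unique, unknown or untested is made for them only; others in the source may bear on it.

Compound 1 `CCCCCCC#Cc1cc2cn([C@H]3C[C@H](O)[C@@H](CO)O3)c(=O)nc2o1` is one of two compounds tested in a functional assay on HEL cells (Homo sapiens) for cytotoxicity (a lower number here means that less compound is tolerated, a higher number that more compound is tolerated), where compound 1 gives 138000 nM, the highest of the two numbers. Within the data shown here, its companion, compound 2 `CCCCCCCCCCC#Cc1cc2cn([C@H]3C[C@H](O)[C@@H](CO)O3)c(=O)nc2o1`, differs only in the chain and gives 36000 nM in this assay, so that the shift a 3.8-fold lower number from compound 1 to compound 2 (0.58 log units; beyond the scatter) is the only measured step available.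

Compound 3 `CCCCCCC#Cc1cc2cn(C)c(=O)nc2o1` has not yet been measured. It differs from compound 1 in this way: methyl in place of 4-hydroxy-5-(hydroxymethyl)oxolan-2-yl on an aromatic nitrogen. Among the measured compounds shown here, the only measured step, from compound 1 to compound 2, concerns the chain and not the group on the aromatic nitrogen, so no measured step bears on this change; nothing in the two numbers speaks to what the exchange on the ring nitrogen does in this assay. The expectation for compound 3 therefore rests on compound 1 alone, with wide uncertainty: the estimated step from compound 1 is a 1.1-fold higher number from compound 1 to compound 3 (0.04 log units; within the scatter), expected to lie within the scatter. Compound 3 is estimated at 150000 nM in this assay, in a range from 40000 nM to 500000 nM.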

Compound 3, half-maximal cytotoxic concentration: > 194000 nM
Compound 3 ended at the assay's limit; the forecaster's own chance of this, stated with the estimate: 30%; middle value at least 1.2-fold (0.11 log units) from the limit.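

In this assay the value of compound 3 is a limit of the assay and not a number: the limit of > 194000 nM in this assay, at which 1 of the 3 values shown sits. Exchanging the 4-hydroxy-5-(hydroxymethyl)oxolan-2-yl group on the aromatic nitrogen for methyl gives an at least 1.4-fold higher number from compound 1 to compound 3 (0.14 log units; that floor lies within the scatter), so this floor alone does not set the two compounds apart, although the true gap could be wider. Among these compounds, the earlier pair spoke only to the chain, whereas this result is the first reading at the aromatic nitrogen, and it shows that tolerance in this assay is not lost when the five-membered non-aromatic ring, with its 2 hydrogen-bond donors and 3 defined stereocentres, gives way to methyl.

Going by these compounds, how far compound 3 lies past its limit remains open, as does whether the longer chain of compound 2 would lower the number in the same way with methyl on the nitrogen. Also open, on these data alone, is how other groups at this position would behave in this assay, such as an ethyl group, a 2-hydroxyethyl chain or a simple hydrogen on the nitrogen, which could show which part of the departing group matters, if any does.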